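The compounds below may be only part of what the source reports. "The series", "measured", "known", "first", "only" and "open" are said of these compounds alone.

Measured in a functional assay on PC-9 cells (Homo sapiens) for inhibition, read by MTT assay, with a stated time of 72 h; a higher number here means a weaker inhibitor, a lower number a stronger inhibitor:
Compound 1 `Cc1cc(Nc2cc(-c3ccccc3)[nH]n2)n2nc(SCCc3ccccc3)nc2n1`: 4930 nM
Compound 2 `Cc1cc(Nc2cc(-c3ccccc3)[nH]n2)n2nc(SCc3c(Cl)cccc3Cl)nc2n1`: 5180 nM
Compound 3 `C#CCSc1nc2nc(C)cc(Nc3cc(-c4ccccc4)[nH]n3)n2n1`: > 50000 nM (a limit of the assay, not a number)

Exchanging benzyl for 2,6-dichlorophenyl on the chain gives a 1.1-fold higher number from compound 1 to compound 2 (0.02 log units; within the scatter). Compound 3 has no number of its own, only (the limit of > 50000 nM in this assay, at which 1 of the 3 values shown sits).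

Compound 4 `Cc1cc(Nc2cc(-c3ccccc3)[nH]n2)n2ncnc2n1` carries hydrogen in place of propargylsulfanyl on an aromatic carbon. Within the data shown here, no measured step makes this exact change. The nearest evidence comes from the two steps that put ethynyl on the chain, an at least 10-fold higher number from compound 1 to compound 3 (1.00 log units; beyond the scatter) and an at least 9.6-fold higher number from compound 2 to compound 3 (0.98 log units; beyond the scatter). Both are bounds only, and both lie beyond the scatter.

Compound 4 has no ring at this place, and neither has compound 3, which stands apart from compound 1 by an at least 10-fold higher number from compound 1 to compound 3 (1.00 log units; beyond the scatter). A return towards the values of the two ring-bearing compounds is therefore not expected, and no step beyond the scatter is foreseen. The expected step is an at least 1.1-fold lower number from compound 3 to compound 4 (0.04 log units; that floor lies within the scatter). For compound 4 the estimated value is 45000 nM, with an expected range from 15000 nM to 120000 nM. this assay may well report only a limit again.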

Compound 4, half-maximal inhibitory concentration: > 50000 nM
Compound 4 was reported as a limit; the forecaster's own chance of this, stated with the estimate: 55%; middle value at least 1.1-fold (0.04 log units) from the limit.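

In this assay compound 4, which carries hydrogen on the aromatic carbon between two ring nitrogen atoms, gives > 50000 nM, a limit of the assay and not a number. Losing the sulfanyl substituent altogether gives an at least 10-fold higher number from compound 1 to compound 4 (1.00 log units; beyond the scatter) and an at least 9.6-fold higher number from compound 2 to compound 4 (0.98 log units; beyond the scatter); both are bounds, and they show that the shared core with hydrogen at this place does not keep the values of the two compounds with a phenyl ring on the sulfanyl chain, so among these four compounds only those two give a number. The step between propargylsulfanyl and hydrogen cannot be read, and the two groups sit at the same ceiling: the limit of > 50000 nM in this assay, at which 2 of the 4 values shown sit.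

How far compound 3 and compound 4 lie from each other beyond that limit stays unknown, so the compounds shown cannot tell whether propargylsulfanyl does anything at all at this place. They also leave open whether the phenyl ring itself is what counts on the sulfur, or whether a longer alkyl chain, an amine or a carboxylic acid at the end of the sulfanyl chain would give a measurable value.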